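Swapping Fluoro for Benzamido on the Aniline Arm

This account rests on a few compounds, and the source may have more. Where it says the series, first, only, none or still open, it means among the compounds named here.

Compound 1 `O=C(O)C(Sc1nc(Cl)cc(Nc2ccc(F)cc2)n1)c1cccc2ccccc12` was tested in an assay on isolated protein for inhibition of Polyunsaturated fatty acid 5-lipoxygenase (Homo sapiens) (a lower number here means a stronger inhibitor, a higher number a weaker inhibitor), where compound 1 gives 3100 nM. Among the compounds with values here, the only comparison so far is compound 2 `CC(C)CCNc1cc(Cl)nc(SC(C(=O)O)c2cccc3ccccc23)n1`, which in this assay gives 2500 nM; the step of a 1.2-fold lower number from compound 1 to compound 2 (0.09 log units; within the scatter) means the two cannot be told apart. Compound 3 `O=C(Nc1ccc(Nc2cc(Cl)nc(SC(C(=O)O)c3cccc4ccccc34)n2)cc1)c1ccccc1` differs from compound 1 by benzamido in place of fluoro on an aromatic carbon. Within the data shown here, no measured step touches this position, and the one known change elsewhere moved nothing beyond the scatter, so no firm direction can be read from it. Compound 3 is therefore expected to stay close, with the estimated step of a 1.7-fold lower number from compound 1 to compound 3 (0.24 log units; within the scatter) and an estimate of 1800 nM, between 450 nM and 7000 nM.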

Compound 3, half-maximal inhibitory concentration: 600 nM
Beside the measured number, compound 3's estimate is 3.0-fold (0.48 log units) above it; the range from low to high includes it.
By their numbers in this assay, from the lowest: compound 3; then compounds 2 and 1 (each within the scatter of the next).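

In this assay, benzamido in place of fluoro gives a 5.2-fold lower number from compound 1 to compound 3 (0.71 log units; beyond the scatter) and so shows that this aromatic carbon, unlike the nitrogen position changed earlier, can respond to a substitution. The position also tolerates a group of nine heavy atoms where a single fluorine stood. Nothing available explains this gain.

The compounds shown leave open whether the amide or its added aromatic ring matters more. A smaller acetamido group or a plain amine at this position would help separate the two.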